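Methoxy to hydroxy on two related cores

The source may hold more compounds than are shown below. What is called first, only, known or untested is meant among the compounds shown, and "the series" means these compounds.

Compound 1 `CCc1cc2cc(OC)cc(C(=O)c3ccc(OC)cc3)c2o1` carries a methoxy on each of its two aromatic parts. In an assay for inhibition of solute carrier family 22 member 12 (Homo sapiens), read by scintillation counting, with a stated time of 60 min, tested at 50 uM (on this read-out lower numbers stand for less inhibition and higher numbers for more inhibition at the one concentration tested (going by the name of the read-out)), compound 1 gives 5.2%. Compound 2 `CCc1cc2cc(OC)cc(C(=O)c3ccc(O)cc3)c2o1` differs from it by hydrogen in place of methyl on an oxygen on an aromatic ring and in this assay compound 2 gives 60%; the step is a number 54.8 percentage points higher from compound 1 to compound 2 (beyond the scatter). Compound 3 `CCc1oc2cc(O)ccc2c1C(=O)c1ccc(OC)cc1` is built on a different core; the difference between the cores of compound 1 and compound 3 is not broken down here. In this assay compound 3 gives 48.3%, above compound 1 and below compound 2, both gaps beyond the usual scatter. Compound 4 `CCc1oc2cc(O)ccc2c1C(=O)c1ccc(O)cc1` has not yet been measured. It differs from compound 3 by hydrogen in place of methyl on an oxygen on an aromatic ring, the same change, at a place described in the same words, that separates compound 1 from compound 2; among these compounds the change appears in two pairs. Because a number 54.8 percentage points higher from compound 1 to compound 2 (beyond the scatter) was large, a rise of the same kind is expected from compound 3 to compound 4. The room is smaller, though, as compound 3 starts from 48.3%, already well above compound 1. The expected step is a number 31.7 percentage points higher from compound 3 to compound 4 (beyond the scatter). Compound 4 is estimated at 80%, expected to fall between 60% and 95%.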

Compound 4, a percentage reported as inhibition, at one concentration (the size of the read-out at that concentration, not a potency): 92.1%
Compound 4: the middle estimate sits 12.1 percentage points below what was measured; the measured number falls inside the stated range.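

In this assay the change from methoxy to hydroxy again raises the read-out on the second core, by a number 43.8 percentage points higher from compound 3 to compound 4 (beyond the scatter) and the two steps can be set side by side: the same change on two cores in this assay, a number 54.8 percentage points higher (beyond the scatter) from compound 1 to compound 2 and a number 43.8 percentage points higher (beyond the scatter) from compound 3 to compound 4, 11 percentage points apart, within the scatter of two such steps.

On these two cores, then, the change carries over in direction and in size, and the first step gave a fair guide to the second. Two pairs show no more than that: they do not establish that the step would hold on any further core, and they give no reason why the change acts as it does.

Going by these compounds, it remains open whether a carboxylic acid or an amine in place of the hydroxy would give a step of like size. Also open, on these data alone, is how the ethyl chain shared by all four compounds bears on the read-out, which a propyl chain in its place would begin to show.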